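The source may report more compounds than this note shows. Statements on the series, on what has been measured and on what is new or still open speak of the compounds shown alone.

Measured compounds:
Compound 1 `Cc1cnc(CN(C)C[C@H]2Cc3c(cccc3N3CCNCC3)CN2)c(C)c1` gives in a functional assay on CCRF-CEM cells for agonist activity at C-X-C chemokine receptor type 4 (Homo sapiens), read by calcium flux, with a stated time of 25 min; on this read-out higher numbers stand for an effect only at larger amounts of compound and lower numbers for an effect already at smaller amounts > 30000 nM, a limit of the assay rather than a number.
Compound 2 `CN(C[C@H]1Cc2c(cccc2N2CCNC(C)(C)C2)CN1)[C@H]1CCCc2cccnc21` gives in this assay > 30000 nM, again only a limit.
Compound 3 `FC1(F)CCC(CN(C[C@H]2Cc3c(cccc3N3CCNCC3)CN2)[C@H]2CCCc3cccnc32)CC1` gives in this assay > 30000 nM, also a limit.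

Compound 2 therefore stands nowhere on a scale of numbers: all that is known of it is a limit, and the same holds for every other value shown, since (the limit of > 30000 nM in this assay, at which 3 of the 3 values shown sit). For the measured compounds named here, no pair of measured compounds differs in a single place, so no measured step can be drawn from these three, and nothing can be said about the size or direction of any change among them.

The unmeasured compound 4 `CN(C[C@H]1Cc2c(cccc2N2CCN3CCC[C@@H]3C2)CN1)[C@H]1CCCc2cccnc21` departs from compound 2 by one change: a group of 9 heavy atoms (7 carbon, 2 nitrogen; one five-membered non-aromatic ring with 1 hetero atom, one six-membered non-aromatic ring with 2 hetero atoms) in place of a group of 8 heavy atoms (6 carbon, 2 nitrogen; one six-membered non-aromatic ring with 2 hetero atoms), on an aromatic carbon. With the shared core and the remaining groups untouched, and with every measured compound sitting at the limit, there is no ground for expecting a step of any size in either direction. Compound 4 is expected to give about 30000 nM in this assay, with a range from 10000 nM to 100000 nM. The step that this estimate means, a number no higher from compound 2 to compound 4 (the limit leaves the size open), is expected to be none beyond the usual scatter, and most likely the assay will again report only a limit.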

Compound 4, half-maximal effective concentration: > 30000 nM
Compound 4 was reported as a limit; the forecaster's own chance of this, stated with the estimate: 85%; the middle value lies on the limit itself.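

In this assay compound 4 gives > 30000 nM, which is a limit of the assay and not a number. Compound 2 is also known only by a limit, so no step can be read between compound 2 and compound 4. The compounds shown leave open how they rank against one another and which change, if any, would yield a measurable value.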